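The compounds below may be only part of what the source reports. "The series", "measured", "known", "first", "only" and "open" are said of these compounds alone.

In a functional assay on G-361 cells (Homo sapiens) for cytotoxicity, read by MTT assay, with a stated time of 3 days (on this read-out higher numbers stand for weaker inhibition and lower numbers for stronger inhibition), compound 1 (`CN1CCN(c2nc(SCc3nc4ccccc4[nH]3)nc(-c3ccccc3)c2C#N)CC1`) reads 14.7 nM and compound 2 (`N#Cc1c(-c2ccccc2)nc(SCc2nc3ccccc3[nH]2)nc1N1CCN(S(=O)(=O)c2ccccc2)CC1`) reads 8.62 nM on the same scale, so compound 2 stands level with compound 1 within the scatter. Compound 3 (`Cc1ccc(S(=O)(=O)N2CCN(c3nc(SCc4nc5ccccc5[nH]4)nc(-c4ccccc4)c3C#N)CC2)cc1`) is compound 2 with methyl in place of hydrogen on an aromatic carbon, para to a large group (methyl in place of hydrogen on an aromatic carbon), taking phenylsulfonyl to (4-methylphenyl)sulfonyl. Going by the values given here, the one measured step bearing on this (a 1.7-fold lower number from compound 1 to compound 2 (0.23 log units; within the scatter)) put phenylsulfonyl in place of methyl on a ring amine nitrogen and stayed within the scatter. No shift beyond the scatter is therefore expected in this assay, in either direction. The estimated step is small (a 1.0-fold higher number from compound 2 to compound 3 (0.02 log units; within the scatter)) and has no firm direction. Compound 3 is estimated at 9 nM with an expected range (4 nM to 20 nM).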

Compound 3, half-maximal inhibitory concentration: 4.38 nM
Compound 3: the middle estimate sits 2.1-fold (0.31 log units) above what was measured; measured number inside the range.
By their numbers in this assay, from the lowest: compounds 3, 2 and 1 (each within the scatter of the next, the first and the last beyond it).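

Methyl in place of hydrogen on an aromatic carbon, para to a large group, gives a 2.0-fold lower number from compound 2 to compound 3 (0.29 log units; within the scatter), so this change alone stays inside the scatter. Together with the change on the ring amine nitrogen, (4-methylphenyl)sulfonyl in place of methyl gives a 3.4-fold lower number from compound 1 to compound 3 (0.53 log units; beyond the scatter), the first step in the series beyond the scatter, though a modest one. No supporting measurement accounts for this step.

Open, from the compounds shown here alone, is whether chloro, methoxy or tert-butyl on that carbon would read like methyl. Also open, going by these compounds, is whether an acetyl group on the ring nitrogen would read like the sulfonyl groups.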